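This account rests on a few compounds, and the source may have more. Where it says the series, first, only, none or still open, it means among the compounds named here.

Measured compounds in a functional assay for agonist activity at G protein-coupled receptor 88 (Homo sapiens), read by HTRF and cAMP accumulation; on this read-out higher numbers stand for an effect only at larger amounts of compound and lower numbers for an effect already at smaller amounts:
compound 1 `CC(C)C[C@H](N)CN(C(=O)[C@@H]1C[C@H]1c1ccccc1)c1ccc(-c2cccnc2)cc1` — 10000 nM
compound 2 `CC(C)C[C@H](N)CN(C(=O)[C@@H]1C[C@H]1c1ccccc1)c1ccc(-c2ccsc2)cc1` — 1200 nM
compound 3 `CC(C)C[C@H](N)CN(C(=O)[C@@H]1C[C@H]1c1ccccc1)c1ccc(-c2cccs2)cc1` — 1500 nM

Compound 3 stands second highest of the three numbers. Its nearest neighbour is compound 2: the step of a 1.3-fold higher number from compound 2 to compound 3 (0.10 log units; within the scatter) lies within the scatter, so the two thiophene isomers cannot be told apart. Going by the values given here, the only steps beyond the scatter are an 8.3-fold lower number from compound 1 to compound 2 (0.92 log units; beyond the scatter) and a 6.7-fold lower number from compound 1 to compound 3 (0.82 log units; beyond the scatter), both from the pyridin-3-yl compound 1 to a thiophene.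

Compound 4 `CC(C)C[C@H](N)CN(C(=O)[C@@H]1C[C@H]1c1ccccc1)c1ccc(C2=CCCCCC2)cc1` takes the step (cyclohept-1-en-1-yl in place of thiophen-2-yl on an aromatic carbon). Among the compounds with values here, no measured pair covers an exchange of an aromatic ring for a non-aromatic carbon ring at this position; the steps that bear on it only show that swapping one five-membered aromatic ring for another leaves this assay essentially unchanged, while the pyridine-to-thiophene change was modest. Within the data shown here, with no direct precedent, the expectation is for a step of about a 1.3-fold higher number from compound 3 to compound 4 (0.12 log units; within the scatter), most likely within or near the scatter, with wide uncertainty in either direction. Compound 4 is therefore estimated at 2000 nM, with a range of 500 nM to 8000 nM.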

Compound 4, half-maximal effective concentration: 2100 nM
The estimate for compound 4 lay 1.1-fold (0.02 log units) below the measured number; the measured number falls inside the stated range.
By their numbers in this assay, from the lowest: compounds 2, 3 and 4 (each within the scatter of the next); then compound 1.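

In this assay this position takes a non-aromatic carbon ring as readily as a thiophene: cyclohept-1-en-1-yl, a seven-membered ring of carbon only, stands within the scatter of both thiophenes (a 1.4-fold higher number from compound 3 to compound 4 (0.15 log units; within the scatter) and a 1.8-fold higher number from compound 2 to compound 4 (0.24 log units; within the scatter)). With a 4.8-fold lower number from compound 1 to compound 4 (0.68 log units; beyond the scatter) beyond the scatter, compound 1 alone stands apart among the four, so neither an aromatic ring nor a sulfur atom is required here for numbers at the level of compound 2 and compound 3. No evidence is available on why these different groups give such similar numbers.

Still open, from the compounds shown here alone, is whether a plain phenyl ring, a saturated cycloheptyl ring or an open hexyl chain would match these numbers at this place. Going by these compounds, it is equally open whether an amine or a carboxylic acid on the cycloheptene ring would shift them.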